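A few compounds are considered here, and "the series" means these few. Any claim that something is new, unique, unknown or untested is made for them only; others in the source may bear on it.

Compound 2 `Cc1nc(Nc2ccc(Cl)cc2)sc1C(=O)/C=C/c1ccccc1` is tested in a functional assay on Bel-7402 cells (Homo sapiens) for cytotoxicity, read by MTT assay; on this read-out higher numbers stand for weaker inhibition and lower numbers for stronger inhibition. In this assay compound 2 gives only a limit, > 25000 nM, and not a number. For the measured compounds named here, the single measured step that leads to compound 2 starts from compound 1 `COc1ccc(/C=C/C(=O)c2sc(Nc3ccc(Cl)cc3)nc2C)cc1`. In this assay compound 1 likewise gives only a limit, > 25000 nM. The step that the two limits leave unreadable from compound 1 to compound 2 cannot be sized, since the limit of > 25000 nM in this assay, at which 2 of the 2 values shown sit, shows both values resting at the same limit.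

Compound 3 `Cc1nc(Nc2cccc(Cl)c2)sc1C(=O)/C=C/c1ccccc1` is not yet measured. Its difference from compound 2 is 3-chlorophenyl in place of 4-chlorophenyl on a nitrogen on an aromatic ring. Going by the values given here, no measured step touches this change, and the only step known is unreadable, so no direction beyond the scatter can be drawn from it. Compound 3 is expected to stand where compound 2 stands, with the value again most likely reported as a limit. The expected step is a step that the limit leaves unreadable from compound 2 to compound 3. The estimate for compound 3 in this assay is 40000 nM, with a range from 15000 nM to 120000 nM.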

Compound 3, half-maximal inhibitory concentration: > 25000 nM
Compound 3: no number, only a limit (the forecaster's own chance of this, stated with the estimate: 80%); the middle value lies beyond the limit too.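

In this assay the step from compound 2 to compound 3 cannot be read, since both compounds give only a limit and not a number: the limit of > 25000 nM in this assay, at which 3 of the 3 values shown sit.

The compounds shown leave open how strongly compound 1, compound 2 and compound 3 act, and whether 3-chlorophenyl and 4-chlorophenyl differ at all in this assay.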